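Swapping Fluoro for Chloro on Compound 3

A few compounds are considered here, and "the series" means these few. Any claim that something is new, unique, unknown or untested is made for them only; others in the source may bear on it.

Compound 1 `Cc1ccc(S(=O)(=O)Nc2ccc3oc(-c4ccccc4)nc3c2)cc1`: 75000 nM
Compound 2 `O=S(=O)(Nc1ccc(-c2nc3ccccc3o2)cc1)c1ccc(Cl)s1`: > 100000 nM (a limit)
Compound 3 `O=S(=O)(Nc1ccc2oc(-c3ccccc3)nc2c1)c1ccc(F)c(C(F)(F)F)c1`: > 100000 nM (a limit)

In an ADME assay on HEK293 cells (Homo sapiens) for cytotoxicity, read by resazurin assay, with a stated time of 48 h (on this read-out higher numbers stand for lower toxicity in this test and lower numbers for higher toxicity in this test), compound 3 gives > 100000 nM, which is a limit and not a number. This places compound 3 at the limit of > 100000 nM in this assay, at which 2 of the 3 values shown sit. Compound 1 alone gives a number, 75000 nM.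

Compound 4 `O=S(=O)(Nc1ccc2oc(-c3ccccc3)nc2c1)c1ccc(Cl)c(C(F)(F)F)c1` differs from compound 3 in one group: chloro in place of fluoro on an aromatic carbon. Chloro takes the place of fluoro on an aromatic carbon, ortho to a trifluoromethyl group. Among the compounds with values here, no measured pair shows this swap, so no step beyond the usual scatter is expected in this assay. The expected step is a number no higher from compound 3 to compound 4 (the limit leaves the size open). Compound 4 is expected at 100000 nM, with an estimated range of 45000 nM to 200000 nM.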

Compound 4, half-maximal cytotoxic concentration: 66000 nM
The estimate for compound 4 lay 1.5-fold (0.18 log units) above the measured number; the measured number falls inside the stated range.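

In this assay, placing chloro instead of fluoro on the aromatic carbon ortho to a trifluoromethyl group gives an at least 1.5-fold lower number from compound 3 to compound 4 (0.18 log units; that floor lies within the scatter). Compound 3 gives > 100000 nM, which is a limit, and it does not stand there alone: the limit of > 100000 nM in this assay, at which 2 of the 4 values shown sit. Going by these compounds, compound 4 gives a number, 66000 nM, so this substitution pattern now has a measured value, but the true size of the step remains unknown.

The compounds shown leave open how an amine or a methoxy group at this position would read. They also leave open whether the same swap would give a similar result without the trifluoromethyl group.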